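The source may hold more compounds than are shown below. What is called first, only, known or untested is meant among the compounds shown, and "the series" means these compounds.

Measured in a functional assay on A549 cells (Homo sapiens) for inhibition, read by CCK-8 assay, with a stated time of 48 h; on this read-out lower numbers stand for stronger inhibition and higher numbers for weaker inhibition:
- compound 1 `COc1cc(-c2ccnc3cc(-c4ccc(F)cc4)nn23)cc(OC)c1OC`: 3800 nM
- compound 2 `COc1cc(-c2cc3nccc(-c4c[nH]c5ccccc45)n3n2)cc(OC)c1OC`: > 10000 nM

The entry for compound 2 is a limit of the assay and not a number.

Going by the values given here, compound 1 therefore stands alone, with 3800 nM as the only true number in this assay. Compound 3 `COc1cc(-c2ccnc3cc(-c4ccc(Cl)cc4)nn23)cc(OC)c1OC` has not yet been measured. It keeps the core of compound 1 and carries chloro in place of fluoro on an aromatic carbon, para to a large group, so that 4-fluorophenyl becomes 4-chlorophenyl (chloro in place of fluoro on an aromatic carbon).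

Among the compounds with values here, no two measured compounds differ in a single place, so the data offer no direct guide to the size of this change. With only one halogen exchanged for another, no shift beyond the usual scatter is expected in this assay, and neither direction is favoured. The expected step of a 1.1-fold lower number from compound 1 to compound 3 (0.04 log units; within the scatter) is accordingly small. This expectation rests on compound 1 at 3800 nM. Compound 3 is estimated at 3500 nM, with an expected range from 1500 nM to 8000 nM.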

Compound 3, half-maximal inhibitory concentration: 3070 nM
For compound 3 the middle estimate is 1.1-fold (0.06 log units) above the measured one, and the stated range covers the measured number.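

In this assay, going by these compounds alone, the exchange of 4-fluorophenyl for 4-chlorophenyl gives a 1.2-fold lower number from compound 1 to compound 3 (0.09 log units; within the scatter), and this is the first step that can be read between two measured compounds differing in one place. At this place, on an aromatic carbon para to a large group, one halogen can therefore stand in for the other without a shift beyond the usual scatter, and the value remains a true number rather than a limit. Compound 2 adds no second step to set beside this one, and its entry is a limit of the assay and not a number: the limit of > 10000 nM in this assay, at which 1 of the 3 values shown sits.

The compounds shown cover only fluoro and chloro at this place, so they leave open whether a group of another kind, such as an amine, a carboxylic acid, a nitrile or a longer alkyl chain, would keep the value of compound 1 or move it beyond the scatter. They also leave open whether plain hydrogen at this place would change the number, and how far any change elsewhere on the shared core would carry.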